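Swapping Trifluoromethyl for Fluoro on an Inactive Pair

This account rests on a few compounds, and the source may have more. Where it says the series, first, only, none or still open, it means among the compounds named here.

Two measured compounds share one core and differ only in the group on the outer aromatic ring. Compound 1 `COc1cc(OC)c2c(=O)cc(/C=C/c3ccc([N+](=O)[O-])cc3)oc2c1` carries a nitro group. In a functional assay on PC-3 cells (Homo sapiens) for antiproliferative activity, read by MTT assay, with a stated time of 12 h (on this read-out lower numbers stand for stronger inhibition and higher numbers for weaker inhibition), compound 1 gives > 40000 nM, which is a limit of the assay rather than a number. Compound 2 `COc1cc(OC)c2c(=O)cc(/C=C/c3ccc(C(F)(F)F)cc3)oc2c1` carries a trifluoromethyl group instead. In this assay compound 2 gives > 40000 nM, again a limit and not a number. The step that the two limits leave unreadable from compound 1 to compound 2 therefore cannot be sized. Compound 2 thus stands at the limit of > 40000 nM in this assay, at which 2 of the 2 values shown sit, with no number of its own.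

Compound 3 `COc1cc(OC)c2c(=O)cc(/C=C/c3ccc(F)cc3)oc2c1` is not yet measured. It differs from compound 2 by fluoro in place of trifluoromethyl on an aromatic carbon. Going by the values given here, only one measured step exists, from compound 1 to compound 2, and it is unreadable because both its values sit at the limit (the limit of > 40000 nM in this assay, at which 2 of the 2 values shown sit). No size or direction for the change to compound 3 in this assay can be drawn from it; the expectation rests on the two limits alone.

Compound 3 is therefore expected to give about 50000 nM, in a range from 10000 nM to 200000 nM, most probably reported again as a limit. The expected step that the limit leaves unreadable from compound 2 to compound 3 is estimated to stay within the usual scatter.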

Compound 3, half-maximal inhibitory concentration: > 40000 nM
Compound 3 ended at the assay's limit; the forecaster's own chance of this, stated with the estimate: 75%; the middle value is on the limit's open side.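

Compound 3, like compound 1 and compound 2, gives a limit rather than a number in this assay, so no step among these three compounds can be read: the limit of > 40000 nM in this assay, at which 3 of the 3 values shown sit.

The compounds shown leave open how nitro, trifluoromethyl and fluoro on the outer aromatic ring compare in this assay, as none of the three compounds has a number of its own.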